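The source may hold more compounds than are shown below. What is called first, only, known or untested is meant among the compounds shown, and "the series" means these compounds.

Compound 3 `Nc1nc(-c2nn(Cc3ccccc3F)c3ncccc23)ncc1C1CCC1` stands second highest of the three numbers in a functional assay (aorta) with Oryctolagus cuniculus as the target; on this read-out higher numbers stand for weaker inhibition and lower numbers for stronger inhibition: compound 3 gives 633000 nM, compound 2 `CC(C)(C)c1cnc(-c2nn(Cc3ccccc3F)c3ncccc23)nc1N` gives 709000 nM, and compound 1 `OCc1ccc(-c2nn(Cc3ccccc3F)c3ncncc23)o1` gives 9400 nM. Compound 3 lies within the scatter of compound 2 and far from compound 1. Compound 4 `CCCS(=O)(=O)c1cnc(-c2nn(Cc3ccccc3F)c3ncccc23)nc1N` differs from compound 3 by propylsulfonyl in place of cyclobutyl on an aromatic carbon. For the measured compounds named here, the only measured step, a 1.1-fold lower number from compound 2 to compound 3 (0.05 log units; within the scatter), exchanges one carbon group for another on an aromatic carbon and gives no guide to a propylsulfonyl. Going by the values given here, no measured step therefore bears on this change, and the expected step in this assay is a 2.5-fold lower number from compound 3 to compound 4 (0.40 log units; beyond the scatter), with no direction that can be relied on. Compound 4 is estimated at 250000 nM, from 50000 nM to 1200000 nM.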

Compound 4, half-maximal inhibitory concentration: 378000 nM
Compound 4: the middle estimate sits 1.5-fold (0.18 log units) below what was measured, within the range that was stated.
By their numbers in this assay, from the lowest: compound 1; then compounds 4, 3 and 2 (each within the scatter of the next).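

In this assay, exchanging the carbon groups on this aromatic carbon, ortho to an amino group, for propylsulfonyl gives no step beyond the scatter: the data show (a 1.7-fold lower number from compound 3 to compound 4 (0.22 log units; within the scatter)) and (a 1.9-fold lower number from compound 2 to compound 4 (0.27 log units; within the scatter)). An open-chain group with two hydrogen-bond acceptors is thus tolerated here as far as this read-out shows, which the exchange of one carbon group for another could not reveal. No supporting measurement bears on why this is so. From the compounds shown here alone, whether an amine, a carboxylic acid or a longer chain at this position would move the number beyond the scatter remains open.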